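Extending the chain from compound 3 to compound 4

The source may report more compounds than this note shows. Statements on the series, on what has been measured and on what is new or still open speak of the compounds shown alone.

Values so far in a functional assay on A549 cells (Homo sapiens) for inhibition, read by sulforhodamine B assay, with a stated time of 72 h (a higher number here means a weaker inhibitor, a lower number a stronger inhibitor), are:
- compound 1 `C#Cc1cccc(Nc2ncnc3cc(OCCCCCn4ccnc4[N+](=O)[O-])c(OC)cc23)c1` gives 770 nM
- compound 2 `COc1cc2c(Nc3cccc(Br)c3)ncnc2cc1OCCCn1ccnc1[N+](=O)[O-]` gives 13500 nM
- compound 3 `COc1cc2c(Nc3cccc(Br)c3)ncnc2cc1OCCCCn1ccnc1[N+](=O)[O-]` gives 3090 nM

Compound 3 holds the middle place of these three numbers, with compound 1 lower and compound 2 higher. The next structure, compound 4 `COc1cc2c(Nc3cccc(Br)c3)ncnc2cc1OCCCCCn1ccnc1[N+](=O)[O-]`, carries one change from compound 3: (2-nitro-1H-imidazol-1-yl)methyl in place of 2-nitro-1H-imidazol-1-yl on a saturated chain carbon, four bonds along the chain from an oxygen on an aromatic ring. Among the compounds with values here, the same exchange, made three bonds along the chain from an oxygen on an aromatic ring, gave a 4.4-fold lower number from compound 2 to compound 3 (0.64 log units; beyond the scatter) and is the only measured step of this kind. Compound 4 shares its chain with compound 1, which gives 770 nM but carries a different group elsewhere. A further modest fall is therefore expected in this assay with an expected size of a 2.4-fold lower number from compound 3 to compound 4 (0.38 log units; beyond the scatter) on this single precedent. Compound 4 is estimated at 1300 nM with an expected range from 500 nM to 3500 nM in this assay.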

Compound 4, half-maximal inhibitory concentration: 8780 nM
Estimate against measurement, compound 4: 6.8-fold (0.83 log units) below; the whole stated range lies below it.
By their numbers in this assay, from the lowest: compound 1; then compound 3; then compounds 4 and 2 (each within the scatter of the next).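

In this assay, lengthening the chain does not keep lowering the number: the earlier fall reverses (a 2.8-fold higher number from compound 3 to compound 4 (0.45 log units; beyond the scatter)), so among the bromo compounds shown compound 3 has the lowest number. The shortest and longest bromo chains are not separated (a 1.5-fold lower number from compound 2 to compound 4 (0.19 log units; within the scatter)), whereas on the same chain, bromo in place of ethynyl matters far more (an 11-fold higher number from compound 1 to compound 4 (1.06 log units; beyond the scatter)). Nothing available bears on why the fall reverses. From the compounds shown here alone, it remains open whether ethynyl compounds on shorter chains show the same turn. Going by these compounds, it is also open how an amine in place of 2-nitro-1H-imidazol-1-yl, or a longer chain, would read.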